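Swapping 2-ethylphenyl for 2,4-dimethylphenyl: an expected half-life

A few compounds are considered here, and "the series" means these few. Any claim that something is new, unique, unknown or untested is made for them only; others in the source may bear on it.

Values in an ADME assay on microsomes from liver (Rattus norvegicus) for metabolic stability, read by LC-MS, using NADPH, at 37 degrees C; on this read-out higher numbers stand for a longer-lived compound and lower numbers for a shorter-lived compound:
Compound 1 `Cc1oc(-c2ccc(Cl)c(Cl)c2)nc1CN1CCC(C(=O)NCCCN2C[C@H](C)C[C@H](C)C2)CC1` gives > 0.5 h
Compound 2 `Cc1oc(-c2c(Cl)cccc2Br)nc1CN1CCC(C(=O)NCCCN2C[C@H](C)C[C@H](C)C2)CC1` gives 0.0233 h
Compound 3 `CCc1ccccc1-c1nc(CN2CCC(C(=O)NCCCN3C[C@H](C)C[C@H](C)C3)CC2)c(C)o1` gives 0.283 h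

The value of compound 1 is a limit of the assay, not a number. Of the two actual numbers, compound 3 holds the higher one, as a 12-fold higher number from compound 2 to compound 3 (1.08 log units; beyond the scatter) shows. Against the limit, the comparison is an at least 1.7-fold lower number from compound 1 to compound 3 (0.24 log units; that floor lies within the scatter) and the remaining step is an at least 21-fold lower number from compound 1 to compound 2 (1.33 log units; beyond the scatter). All three steps change the group at the same place, and two are large, but none compares the two groups now in question.

Compound 4 `Cc1ccc(-c2nc(CN3CCC(C(=O)NCCCN4C[C@H](C)C[C@H](C)C4)CC3)c(C)o2)c(C)c1` differs from compound 3 as follows: 2,4-dimethylphenyl in place of 2-ethylphenyl on an aromatic carbon. The change is 2,4-dimethylphenyl in place of 2-ethylphenyl on an aromatic carbon. The expected step is small: a 1.4-fold lower number from compound 3 to compound 4 (0.15 log units; within the scatter), within the scatter. For compound 4 the estimated half-life is 0.2 h, with an expected range from 0.07 h to 0.5 h in this assay.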

Compound 4, half-life: > 0.5 h
Compound 4 was reported as a limit (the forecaster's own chance of this, stated with the estimate: 10%); middle value at least 2.5-fold (0.39 log units) away from the limit.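

The value of compound 4 is a limit, not a number. Replacing 2-ethylphenyl with 2,4-dimethylphenyl on this aromatic carbon gives an at least 1.7-fold higher number from compound 3 to compound 4 (0.24 log units; that floor lies within the scatter), so this change of an isomeric group is not shown to shift the half-life, while the replacement of 2-bromo-6-chlorophenyl gives an at least 21-fold higher number from compound 2 to compound 4 (1.33 log units; beyond the scatter). The steps between compound 1 and compound 4 cannot be read, because both values are limits: the limit of > 0.5 h in this assay, at which 2 of the 4 values shown sit.

Going by these compounds, how far compound 4 lies past its limit stays open. Also open, on these data alone, is how a 2-methoxyphenyl or a 2,4-difluorophenyl group would behave at this place.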